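Chloro for fluoro on the fused ring of compound 1

A few compounds are considered here, and "the series" means these few. Any claim that something is new, unique, unknown or untested is made for them only; others in the source may bear on it.

Of the compounds shown here, three have been measured in an assay for binding affinity to CDK8/Cyclin C (Homo sapiens), read by FRET and LanthaScreen, with stated times of 20 min and 2 h, tested at 10 uM; on this read-out higher numbers stand for more inhibition at the one concentration tested (going by the name of the read-out) and lower numbers for less inhibition. Compound 1 `CCOc1ccc(C(=O)c2cnc3ccc(F)cc3c2N2CCCC2)cc1` gives 50%. Compound 3 `COc1cc(-c2nc3cnccn3c2Nc2cccc(Cl)c2)ccc1O` gives 41%, and that gap from compound 1 lies within the scatter, so the two cannot be ranked. Compound 2 `COc1ccc(Nc2c(-c3cccc(O)c3)nc3ncccn23)cc1OC` gives 17%, a gap from compound 1 that lies beyond the scatter. Within the data shown here, the three compounds share no single-point change with each other, so no step between measured pairs can be quoted.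

Compound 4 `CCOc1ccc(C(=O)c2cnc3ccc(Cl)cc3c2N2CCCC2)cc1` has not yet been measured. It differs from compound 1 by chloro in place of fluoro on an aromatic carbon. With no measured halogen exchange in this series to lean on, the step from compound 1 to compound 4 is expected to be small, in either direction, and most likely not beyond the scatter; the expected step is a number 2 percentage points higher from compound 1 to compound 4 (within the scatter). Compound 4 is therefore estimated at 52% in this assay, with a range of 35% to 70%.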

Compound 4, a percentage reported as inhibition, at one concentration (the size of the read-out at that concentration, not a potency): 46%
Compound 4: middle estimate off by 6 percentage points, on the high side; the measured number falls inside the stated range.
By their numbers in this assay, from the lowest: compound 2; then compounds 3, 4 and 1 (each within the scatter of the next).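

Among these compounds, the first single-point step is now available: in this assay, chloro in place of fluoro on the aromatic carbon of the fused system gives a number 4 percentage points lower from compound 1 to compound 4 (within the scatter). At this position, the read-out therefore does not separate the two halogens at the one concentration tested, and this one exchange gives no handle for ranking them. No measurement at hand speaks to the reason for this outcome.

Going by these compounds, whether a methoxy group, a nitrile or a plain hydrogen on this same carbon would move the number beyond the scatter remains open. Also open, on these data alone, is whether compound 1 and compound 4 would differ in a full potency measurement, as a reading at one concentration is not a potency.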